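This account rests on a few compounds, and the source may have more. Where it says the series, first, only, none or still open, it means among the compounds named here.

Compound 1 `CCOC(=O)C(=O)Nc1nc(-c2ccc(F)cc2)cs1`: > 10 mg/kg
Compound 2 `CCOC(=O)C(=O)Nc1nc(-c2ccc(N(C)C)cc2)cs1`: about 1 mg/kg

For the measured compounds named here, in a functional assay on the whole organism with Rattus norvegicus as the target (on this read-out lower numbers stand for an effect already at smaller amounts and higher numbers for an effect only at larger amounts of compound), compound 2 gives about 1 mg/kg, the only actual number so far. Compound 1 gives > 10 mg/kg, which is a limit. Compound 3 `CCOC(=O)C(=O)Nc1ccc(-c2csc(NC(=O)C(=O)OCC)n2)cc1` carries ((ethoxycarbonyl)carbonyl)amino in place of dimethylamino on an aromatic carbon. Going by the values given here, the only measured step, an at least 10-fold lower number from compound 1 to compound 2 (1.00 log units; beyond the scatter), changed this same place and went beyond the scatter, so another change there may well matter too. That step does not cover the entering group, so a moderate expected rise is assumed, and the estimated step is a 3.0-fold higher number from compound 2 to compound 3 (0.48 log units; beyond the scatter). The estimate for compound 3 is 3 mg/kg, with an expected range from 0.5 mg/kg to 20 mg/kg.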

Compound 3, dose for half-maximal effect: > 30 mg/kg
Compound 3 was reported as a limit; the forecaster's own chance of this, stated with the estimate: 30%; middle value at least 10-fold (1.00 log units) from the limit.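

At this place on the ring, para to a large group, the change from dimethylamino to the larger ((ethoxycarbonyl)carbonyl)amino gave an at least 30-fold higher number from compound 2 to compound 3 (1.47 log units; beyond the scatter), so the same position that produced the earlier gain can also produce a large loss. The step between compound 1 and compound 3 cannot be read, as both values are limits. The value of compound 3 in this assay is also only a limit: the limit of > 30 mg/kg in this assay, at which 1 of the 3 values shown sits.

From the compounds shown here alone, how a primary amine, diethylamino or a carboxylic acid would fare at this place stays open.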